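A few compounds are considered here, and "the series" means these few. Any claim that something is new, unique, unknown or untested is made for them only; others in the source may bear on it.

The study compares two cores. Compound 1 `C=CCn1ncc2c(C)nc(C)n2c1=O` and compound 3 `C=CCn1ncc2c(C)nc(CCC)n2c1=O` share one core, while compound 2 `Cc1ncn2c(Nc3cc[nH]n3)nccc12` and the unmeasured compound 4 `CCCc1ncn2c(Nc3cc[nH]n3)nccc12` share the other; the difference between the two cores is not broken down here. In a functional assay for inhibition, with Homo sapiens as the target (a higher number here means a weaker inhibitor, a lower number a stronger inhibitor), compound 1 gives 73000 nM, and compound 3 gives 40000 nM. The difference between them, (ethyl in place of hydrogen on a saturated chain carbon bound to an aromatic carbon), produced a 1.8-fold lower number from compound 1 to compound 3 (0.26 log units; within the scatter). In this assay compound 2 gives 57000 nM, a number within the scatter of that of compound 1, so no order between them can be claimed. Among the measured compounds shown here, the difference between compound 2 and compound 4 is the same kind of change, (ethyl in place of hydrogen on a saturated chain carbon bound to an aromatic carbon), at a place described in the same words, so the earlier step is the only guide available. Because the earlier step was a 1.8-fold lower number from compound 1 to compound 3 (0.26 log units; within the scatter), the step expected for compound 4 in this assay is a 1.6-fold lower number from compound 2 to compound 4 (0.21 log units; within the scatter), small and within the scatter. In this assay compound 4 is therefore estimated at 35000 nM, most likely between 15000 nM and 90000 nM.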

Compound 4, half-maximal inhibitory concentration: > 48000 nM
Compound 4: no number, only a limit (the forecaster's own chance of this, stated with the estimate: 15%); middle value at least 1.3-fold (0.13 log units) from the limit.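

No new step can be read from compound 2 to compound 4, because compound 4 carries a limit of the assay and not a number: the limit of > 48000 nM in this assay, at which 1 of the 4 values shown sits.

The compounds shown leave open whether ethyl in place of hydrogen changes the number on the core of compound 2 as it does on the core of compound 1.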